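A few compounds are considered here, and "the series" means these few. Any claim that something is new, unique, unknown or untested is made for them only; others in the source may bear on it.

In a functional assay on the whole organism for inhibition, with Scenedesmus acutus as the target (on this read-out higher numbers stand for weaker inhibition and lower numbers for stronger inhibition), three compounds sharing one core have been measured so far. Compound 1 `CCCOC(=O)c1cc(N2C(=O)C3=C(CCCC3)C2=O)c(F)cc1Cl` gives 33.1 nM, compound 3 `CC(C)COC(=O)c1cc(N2C(=O)C3=C(CCCC3)C2=O)c(F)cc1Cl` gives 100 nM, and compound 2 `CCCOC(=O)c1cc(N2C(=O)C3=C(CCCC3)C2=O)ccc1Cl` gives 1120 nM, the highest number of the three. Compound 4 `CCC(C)OC(=O)c1cc(N2C(=O)C3=C(CCCC3)C2=O)ccc1Cl` has not yet been measured. It differs from compound 2 in one place, where propoxycarbonyl becomes sec-butoxycarbonyl: methyl in place of hydrogen on a saturated chain carbon bound to an oxygen next to a carbonyl group and a saturated chain carbon.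

Two measured steps deserve a look. Putting hydrogen in place of fluoro on an aromatic carbon gave a 34-fold higher number from compound 1 to compound 2 (1.53 log units; beyond the scatter), a large step, but compound 4 keeps that same hydrogen, so this change is not repeated. The closer guide is the extra methyl of compound 3, which gave a 3.0-fold higher number from compound 1 to compound 3 (0.48 log units; beyond the scatter), a modest step towards weaker inhibition. This guide is imperfect: that methyl sits on a saturated chain carbon bound to two saturated chain carbons, and compound 3 carries fluoro. Among the measured compounds shown here, no measured pair shows a methyl at the new place.

A small to modest rise in the number is therefore expected, and no change beyond the scatter would not be surprising. The expected step is a 2.0-fold higher number from compound 2 to compound 4 (0.29 log units; within the scatter). The estimate for compound 4 is 2200 nM, with an expected range of 700 nM to 7000 nM.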

Compound 4, half-maximal inhibitory concentration: 1100 nM
Compound 4: middle estimate off by 2.0-fold (0.30 log units), on the high side; the range from low to high includes it.
By their numbers in this assay, from the lowest: compound 1; then compound 3; then compounds 4 and 2 (each within the scatter of the next).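

The extra methyl on the saturated chain carbon bound to an oxygen next to a carbonyl group and a saturated chain carbon leaves compounds 2 and 4 indistinguishable in this assay, with a 1.0-fold lower number from compound 2 to compound 4 (0.01 log units; within the scatter). Among the compounds shown here, on this fluoro-free core, then, sec-butoxycarbonyl is accepted in place of propoxycarbonyl with no measurable loss of inhibition, which the earlier compounds could not show. Adding a methyl to this ester chain therefore does not have one fixed effect across the two cores: the same change on two cores in this assay, a 3.0-fold higher number (0.48 log units; beyond the scatter) from compound 1 to compound 3 and a 1.0-fold lower number (0.01 log units; within the scatter) from compound 2 to compound 4, 3.1-fold (0.49 log units) apart, beyond the scatter of two such steps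

The two steps differ both in which chain carbon carries the methyl and in whether fluoro is present, so the compounds shown cannot say which of these differences accounts for the gap; sec-butoxycarbonyl on the fluoro-bearing core of compound 1 would help to separate them. Also open, as far as these compounds go, is how much more this part of the molecule accepts, for example whether a longer chain such as hexyl in the ester, or a carboxylic acid in place of the ester, would keep the inhibition seen here.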